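Bromo to hydrogen on the fused ring of compound 3

The compounds below may be only part of what the source reports. "The series", "measured", "known", "first", "only" and "open" are said of these compounds alone.

Of the compounds shown here, three have been measured in a functional assay on MCF7 cells (Homo sapiens) for cytotoxicity, read by sulforhodamine B assay, with a stated time of 48 h; on this read-out higher numbers stand for weaker inhibition of growth and lower numbers for stronger inhibition of growth. Compound 1 `O=C1C(=O)N(CN2CCN(c3ccnc4cc(Cl)ccc34)CC2)c2cccc(Cl)c21` gives 39100 nM. Compound 2 `NC(=S)N/N=C1/C(=O)N(CN2CCN(c3ccnc4cc(Cl)ccc34)CC2)c2cccc(Br)c21` gives 46600 nM, and compound 3 `NC(=S)N/N=C1/C(=O)N(CN2CCN(c3ccnc4cc(C(F)(F)F)ccc34)CC2)c2cccc(Br)c21` gives 50600 nM. Compound 3 carries the highest of the three numbers, yet its gaps to compound 2 and to compound 1 are both within the scatter, so the three stand together at one level. Among the compounds with values here, the single one-site step measured, a 1.1-fold higher number from compound 2 to compound 3 (0.04 log units; within the scatter), also lies within the scatter.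

Compound 4 `NC(=S)N/N=C1/C(=O)N(CN2CCN(c3ccnc4cc(C(F)(F)F)ccc34)CC2)c2ccccc21` differs from compound 3 by hydrogen in place of bromo on an aromatic carbon. Within the data shown here, no measured step touches this site: the one step seen concerns trifluoromethyl in place of chloro elsewhere and was within the scatter, and compound 1 differs from the others in more than one place. With nothing in this assay moving beyond the scatter so far, no step beyond the scatter is expected here either; the expected step is a 1.0-fold lower number from compound 3 to compound 4 (0.01 log units; within the scatter). Compound 4 is therefore estimated at 50000 nM, within a range of 22000 nM to 115000 nM.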

Compound 4, concentration for 50% growth inhibition: 13900 nM
The estimate for compound 4 lay 3.6-fold (0.56 log units) above the measured number; the measured number lies below the stated range.
By their numbers in this assay, from the lowest: compound 4; then compounds 1, 2 and 3 (each within the scatter of the next).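

Hydrogen in place of bromo on this aromatic carbon, ortho to a fused ring and meta to a fused ring, gives the first one-site step beyond the scatter in this assay: a 3.6-fold lower number from compound 3 to compound 4 (0.56 log units; beyond the scatter). The earlier step at another site, a 1.1-fold higher number from compound 2 to compound 3 (0.04 log units; within the scatter), stayed within the scatter, so this position is the only site shown so far where a single change moves the number. The bromo is therefore not needed for growth inhibition in compound 4's setting, where losing it brings a stronger result, though nothing at hand explains this change.

From the compounds shown here alone, it remains open whether hydrogen in place of bromo gives a step of similar size with chloro in place of trifluoromethyl. Also open, going by these compounds, is how a fluoro, a methoxy or an amine on this same aromatic carbon would compare with hydrogen and bromo.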